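The source may hold more compounds than are shown below. What is called first, only, known or untested is meant among the compounds shown, and "the series" means these compounds.

Compound 1 `COc1ccccc1-c1cccc(S(=O)(=O)N2CCC(N3CCC(C)CC3)CC2)c1`: 21 nM; compound 2 `CC1CCN(C2CCN(S(=O)(=O)c3ccc(F)cc3F)CC2)CC1`: 102 nM; compound 3 `CC1CCN(C2CCN(S(=O)(=O)c3ccccc3-c3ccc(C(F)(F)F)cc3)CC2)CC1`: 122 nM.

In a functional assay on DLD-1 cells (Homo sapiens) for antiproliferative activity, read by CellTiter-Glo, with a stated time of 72 h (a lower number here means a stronger inhibitor, a higher number a weaker inhibitor), compound 2 gives the second highest of the three numbers. Its nearest neighbour is compound 3, whose number is within the scatter of it, so no order between the two can be read. Its furthest neighbour is compound 1, whose number lies beyond the scatter, lower than that of compound 2.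

Compound 4 `CC1CCN(C2CCN(S(=O)(=O)c3ccc(C#N)cc3)CC2)CC1` differs from compound 2 in one place: 4-cyanophenyl in place of 2,4-difluorophenyl on a sulfonyl sulfur. Among the measured compounds shown here, no measured pair shows this exact change, so its size is open. The step from compound 2 to compound 4 in this assay is expected to be small, a 1.1-fold higher number from compound 2 to compound 4 (0.03 log units; within the scatter), likely within the scatter in either direction. The value for compound 4 is estimated at 110 nM, with a range from 40 nM to 300 nM.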

Compound 4, half-maximal inhibitory concentration: 2800 nM
Compound 4: middle estimate off by 25-fold (1.41 log units), on the low side; measured number outside the range, above it.
By their numbers in this assay, from the lowest: compound 1; then compounds 2 and 3 (each within the scatter of the next); then compound 4.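

In this assay the group on the sulfonyl sulfur proves far from interchangeable: 4-cyanophenyl in place of 2,4-difluorophenyl gives a 27-fold higher number from compound 2 to compound 4 (1.44 log units; beyond the scatter) even though both groups are one six-membered aromatic ring with the same count of heavy atoms. Among the compounds shown here, this is the first single-place step available, and it shows that this position can respond strongly to a change of group. No supporting data account for the size of this step. The compounds shown leave open whether the nitrile or the absence of the fluorines carries the step, and how a plain phenyl or an amide in place of the nitrile would stand.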